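Working notes: sulfonyl exchange from compound 3 to compound 4

The compounds below may be only part of what the source reports. "The series", "measured", "known", "first", "only" and "open" are said of these compounds alone.

- compound 1 `O=C(/C(=C\c1ccc(O)c([N+](=O)[O-])c1)SCc1ccc(Br)cc1)c1c(F)c(F)c(F)c(F)c1F` gives 10000 nM
- compound 2 `Cc1ccc(/C=C(\C(=O)c2ccc([N+](=O)[O-])cc2)S(=O)(=O)Cc2ccc(Cl)cc2)s1` gives 25000 nM
- compound 3 `COc1ccc(S(=O)(=O)/C(=C/c2ccc(C)s2)C(=O)c2ccc(Cl)cc2)cc1` gives 25000 nM

All three values come from a functional assay on DU-145 cells (Homo sapiens) for inhibition, read by trypan blue exclusion, with a stated time of 96 h; a lower number here means a stronger inhibitor of growth, a higher number a weaker inhibitor of growth. Compound 2 and compound 3 stand level, and compound 3, at 25000 nM, shares the highest of the three numbers. Compound 1, at 10000 nM, has the lower number, a gap beyond the scatter.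

The next compound to be measured is compound 4 `Cc1ccc(/C=C(\C(=O)c2ccc(Cl)cc2)S(=O)(=O)Cc2ccc(Cl)cc2Cl)s1`. Its difference from compound 3 is 2,4-dichlorobenzyl in place of 4-methoxyphenyl on a sulfonyl sulfur, in words 2,4-dichlorobenzyl in place of 4-methoxyphenyl on a sulfonyl sulfur. Among the compounds with values here, no pair of measured compounds differs in one place only, so this exchange has no direct precedent. The nearest guide is compound 2, which also carries a chlorinated benzyl group on a sulfonyl sulfur and gives 25000 nM, although it differs from compound 4 elsewhere too. In this assay, no change beyond the scatter is therefore expected. The estimated step is a 1.3-fold lower number from compound 3 to compound 4 (0.10 log units; within the scatter), which is expected to stay within the scatter. For compound 4 the estimate is 20000 nM, with an expected range of 8000 nM to 40000 nM.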

Compound 4, concentration for 50% growth inhibition: 10000 nM
Compound 4: middle estimate off by 2.0-fold (0.30 log units), on the high side; the measured number falls inside the stated range.
By their numbers in this assay, from the lowest: compounds 1 and 4 (each within the scatter of the next); then compounds 2 and 3 (each within the scatter of the next).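

In this assay, within the data shown here, the exchange of 4-methoxyphenyl for 2,4-dichlorobenzyl on a sulfonyl sulfur gives a 2.5-fold lower number from compound 3 to compound 4 (0.40 log units; beyond the scatter) as the first step that can be read at a single place. The earlier compounds shown here differed in more than one place and could not show this: the group on the sulfonyl sulfur, with the rest of compound 3 held fixed, does move the number for growth inhibition, and the change runs towards a stronger inhibitor of growth. The exchange alters both the link to the ring, phenyl against benzyl, and the ring substituents, methoxy against chlorine, and no measurement in hand bears on why the number falls.

The compounds shown leave open whether the benzyl link or the chlorines carry the step: 4-methoxybenzyl and 2,4-dichlorophenyl on the same sulfur would separate the two. From the compounds shown here alone, what an amine or a carboxylic acid on that ring would do to the number also remains open.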